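Trading Methoxy for Formyl on a Melanoma Cell Line

The compounds below may be only part of what the source reports. "The series", "measured", "known", "first", "only" and "open" are said of these compounds alone.

Within the data shown here, compound 2 `COc1ccc(-c2cn3ccnc3c(-c3ccc4ncn(C5CCCCC5)c4c3)n2)cc1` stands higher of the two numbers measured so far in a functional assay on SK-MEL-28 cells (Homo sapiens) for inhibition, read by sulforhodamine B assay, with a stated time of 48 h, tested at 10 uM; on this read-out lower numbers stand for less inhibition and higher numbers for more inhibition at the one concentration tested (going by the name of the read-out): compound 2 gives 47.7%, while compound 1 `c1ccc(-c2cn3ccnc3c(-c3ccc4ncn(C5CCCCC5)c4c3)n2)cc1` gives 18%, a gap of a number 29.7 percentage points higher from compound 1 to compound 2 (beyond the scatter). Compound 3 `O=Cc1ccc(-c2cn3ccnc3c(-c3ccc4ncn(C5CCCCC5)c4c3)n2)cc1` differs from compound 2 by formyl in place of methoxy on an aromatic carbon. Among the measured compounds shown here, only that one step bears on this change, and it placed methoxy in place of hydrogen rather than formyl in place of methoxy, so it gives weak guidance. A modest fall back toward compound 1 is expected, a step of a number 12.7 percentage points lower from compound 2 to compound 3 (beyond the scatter). Compound 3 is therefore estimated at 35%, within a range from 10% to 65%.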

Compound 3, a percentage reported as inhibition, at one concentration (the size of the read-out at that concentration, not a potency): 7.54%
The estimate for compound 3 lay 27.5 percentage points above the measured number; measured number outside the range, below it.
By their numbers in this assay, from the lowest: compound 3; then compound 1; then compound 2.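

Swapping methoxy for formyl on this aromatic carbon keeps the heavy-atom count the same, yet it moves the read-out in this assay a long way (a number 40.2 percentage points lower from compound 2 to compound 3 (beyond the scatter)). Formyl also falls short of plain hydrogen (a number 10.5 percentage points lower from compound 1 to compound 3 (beyond the scatter)), so a change at this position can lower the number as well as raise it. Nothing at hand explains this gap. As far as these compounds go, whether an amine or a carboxylic acid here would land nearer methoxy or formyl remains open. So does whether a longer ether, such as ethoxy, would keep the rise seen with methoxy.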